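Two Limits and a Hydroxy Replacement

The source may hold more compounds than are shown below. What is called first, only, known or untested is meant among the compounds shown, and "the series" means these compounds.

In a functional assay on TOV21G cells (Homo sapiens) for antiproliferative activity, read by sulforhodamine B assay, with a stated time of 3 days (a lower number here means a stronger inhibitor of growth, a higher number a weaker inhibitor of growth), compound 1 `Cc1cc(-c2nc(-c3ccc4[nH]c(=O)oc4c3)cs2)ccc1F` gives > 50000 nM, which is a limit and not a number. Compound 2 `O=c1[nH]c2ccc(-c3csc(-c4ccc(F)c(C(F)(F)F)c4)n3)cc2o1` gives > 50000 nM, also a limit. Compound 2 thus stands at the limit of > 50000 nM in this assay, at which 2 of the 2 values shown sit. Within the data shown here, the only measured step is a step that the two limits leave unreadable from compound 1 to compound 2, so it offers no size to carry forward. Compound 3 `O=c1[nH]c2ccc(-c3csc(-c4ccc(F)c(O)c4)n3)cc2o1` has hydroxy in place of trifluoromethyl on an aromatic carbon, ortho to a fluoro group (hydroxy in place of trifluoromethyl on an aromatic carbon). With no readable size to guide it, the expected change in this assay is a modest one toward stronger inhibition, estimated as an at least 1.2-fold lower number from compound 2 to compound 3 (0.09 log units; that floor lies within the scatter). For compound 3 the estimated value is 40000 nM, with an expected range from 8000 nM to 100000 nM.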

Compound 3, concentration for 50% growth inhibition: > 50000 nM
Compound 3 gave a limit, no number (the forecaster's own chance of this, stated with the estimate: 70%); middle value at least 1.2-fold (0.09 log units) from the limit.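

Among these compounds, compound 1, compound 2 and compound 3 all give limits and no numbers, so no step among them can be read: the limit of > 50000 nM in this assay, at which 3 of the 3 values shown sit.

As far as these compounds go, how methyl, trifluoromethyl and hydroxy compare in this assay stays open.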